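The compounds below may be only part of what the source reports. "The series", "measured", "known", "first", "only" and "open" are said of these compounds alone.

In a functional assay on COLO 205 cells (Homo sapiens) for cytotoxicity, read by MTT assay, with a stated time of 72 h (a lower number here means a stronger inhibitor, a higher number a weaker inhibitor), three compounds have been measured so far:

Compound 1 `COc1ccc(C(=O)c2cc(OC)c(OC)c(OC)c2)cc1NC(=O)/C=C/c1ccc(F)cc1`: 3400 nM
Compound 2 `COc1ccc(C(=O)c2cc(OC)c(OC)c(OC)c2)cc1NC(=O)/C=C/c1ccc(C(F)(F)F)cc1`: 2600 nM
Compound 3 `COc1ccc(C(=O)c2cc(OC)c(OC)c(OC)c2)cc1NC(=O)/C=C/c1ccc(F)c(F)c1`: 6020 nM

Compound 2 gives the lowest of these three numbers in this assay. Its nearest neighbour is compound 1, and the step of a 1.3-fold lower number from compound 1 to compound 2 (0.12 log units; within the scatter) lies within the scatter, so the two cannot be told apart. The step of a 2.3-fold higher number from compound 2 to compound 3 (0.36 log units; beyond the scatter) is beyond the scatter, though only modestly so, and the step of a 1.8-fold higher number from compound 1 to compound 3 (0.25 log units; within the scatter) is within it. All three measured steps concern the group on the double-bonded chain carbon: fluoro, trifluoromethyl or 3,4-difluorophenyl.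

Compound 4 `COc1cc(C(=O)c2cc(OC)c(OC)c(OC)c2)cc(NC(=O)/C=C/c2ccc(C(F)(F)F)cc2)c1OC` differs from compound 2 elsewhere: methoxy in place of hydrogen on an aromatic carbon. Going by the values given here, no measured step touches this part of the shared core, so none of them bears directly on the change, and the three cinnamoyl-side steps only show that the numbers in this assay cluster within a narrow band. The expected step of a 1.2-fold higher number from compound 2 to compound 4 (0.06 log units; within the scatter) is therefore no change beyond the scatter, with a wide range to reflect the lack of a direct comparison. Compound 4 is thus estimated to give 3000 nM, between 1000 nM and 9000 nM.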

Compound 4, half-maximal inhibitory concentration: 2500 nM
The estimate for compound 4 lay 1.2-fold (0.08 log units) above the measured number; low and high end bracket the measured number.
By their numbers in this assay, from the lowest: compounds 4, 2, 1 and 3 (each within the scatter of the next, the first and the last beyond it).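

In this assay placing methoxy in place of hydrogen, on the aromatic carbon ortho to a methoxy group, gives the step of a 1.0-fold lower number from compound 2 to compound 4 (0.02 log units; within the scatter) and this lies within the scatter, so compound 2 and compound 4 cannot be told apart. Going by these compounds alone, this is the first direct reading at this position of the shared core, and it shows that, with the trifluoromethyl group of compound 2 kept, this carbon carries a methoxy group without a difference that this read-out can resolve. No measured information is available to explain this result. The compounds shown leave open whether the same holds alongside the fluoro group of compound 1 or the two fluoro groups of compound 3. They also leave open how an amine, a hydroxyl group or a longer alkoxy chain would read at this carbon.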